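The source may hold more compounds than are shown below. What is called first, only, known or untested is meant among the compounds shown, and "the series" means these compounds.

Working notes on the series. Of the compounds shown here, two have been measured in an ADME assay on microsomes from liver (Homo sapiens) for metabolic stability, with a stated time of 30 min; a higher number here means that more of the compound is left, a lower number that less of the compound is left. Compound 1 `CC#CCOC(=O)Cc1c(C(C)C)nc(CCCC)n(Cc2ccc(-c3ccccc3-c3noc(=O)[nH]3)cc2)c1=O` gives 13.7% in this assay. Compound 2 `CCCCc1nc(C)c(CC(=O)OCC2CC2)c(=O)n1Cc1ccc(-c2ccccc2-c2noc(=O)[nH]2)cc1` gives 20% in this assay; its value and that of compound 1 lie within the usual scatter of each other, so neither compound is set apart on the numbers shown.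

Compound 3 `CC#CCOC(=O)Cc1c(C)nc(CCCC)n(Cc2ccc(-c3ccccc3-c3noc(=O)[nH]3)cc2)c1=O` remains to be measured. It differs from compound 2 in one place: prop-1-yn-1-yl in place of cyclopropyl on a saturated chain carbon bound to an oxygen next to a carbonyl group. The rest of the structure, including the methyl group on the shared core, stays as in compound 2. For the measured compounds named here, no step between measured compounds covers this change on its own. Since compound 1 already carries the but-2-yn-1-yl ester and gives 13.7%, the expected step from compound 2 to compound 3 in this assay is small, if anything a slight decrease, a number 4 percentage points lower from compound 2 to compound 3 (within the scatter), not beyond the scatter. Compound 3 is therefore estimated at 16% in this assay, with a range from 8% to 28%.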

Compound 3, percent of the compound remaining: 32%
Compound 3: the middle estimate sits 16 percentage points below what was measured; measured number above the stated range.
By their numbers in this assay, from the lowest: compounds 1 and 2 (each within the scatter of the next); then compound 3.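

In this assay, the place on a saturated chain carbon bound to an oxygen next to a carbonyl group now has a readable step: with the methyl group held, prop-1-yn-1-yl in place of cyclopropyl gives a number 12 percentage points higher from compound 2 to compound 3 (beyond the scatter) in the percent remaining. The aromatic carbon also has its first readable step: with the but-2-yn-1-yl ester held, methyl in place of isopropyl gives a number 18.3 percentage points higher from compound 1 to compound 3 (beyond the scatter) in the same read-out. No measurement shown accounts for either step.

On these data alone, it remains open whether the cyclopropylmethyl ester would follow the same step with isopropyl on the aromatic carbon. The compounds shown also leave open how an ethyl group on that carbon, or a carboxylic acid in place of the ester, would read in this assay.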